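Nitroimidazole piperazines: cytotoxicity working notes

The compounds below may be only part of what the source reports. "The series", "measured", "known", "first", "only" and "open" are said of these compounds alone.

Measured so far:
compound 1 `CCN1CCN(C(=S)SCC(O)Cn2c([N+](=O)[O-])cnc2C)CC1`
compound 2 `Cc1ncc([N+](=O)[O-])n1CC(O)CSC(=S)N1CCN(c2ccccc2)CC1`
compound 3 `CCN1CCN(CC(O)Cn2c([N+](=O)[O-])cnc2C)CC1`

In a toxicity assay on HeLa cells (Homo sapiens) for cytotoxicity, read by MTT assay, with a stated time of 24 h (a higher number here means a weaker inhibitor, a lower number a stronger inhibitor), compound 1 reaches only a limit, > 5000000 nM. Compound 2 also reaches only a limit in this assay, > 5000000 nM. Within the data shown here, compound 3 is the one compound with a number in this assay, giving 4940000 nM. The change from compound 1 to compound 2, (phenyl in place of ethyl on an amine nitrogen in a ring), gives a step that the two limits leave unreadable from compound 1 to compound 2, since the limit of > 5000000 nM in this assay, at which 2 of the 3 values shown sit, covers both ends. How the core of compound 3 differs from the core of compound 1 is not broken down here. Compound 4 `Cc1ncc([N+](=O)[O-])n1CC(O)CN1CCN(c2ccccc2)CC1` carries the same change on the core of compound 3: phenyl in place of ethyl on an amine nitrogen in a ring. The step from compound 1 to compound 2 gives no readable size to carry over. Compound 4 is expected to give about 5000000 nM in this assay, between 2000000 nM and 12000000 nM, the expected step being a 1.0-fold higher number from compound 3 to compound 4 (0.01 log units; within the scatter). This expectation rests on compound 3 because it gives 4940000 nM. It rests also on (the limit of > 5000000 nM in this assay, at which 2 of the 3 values shown sit).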

Compound 4, half-maximal inhibitory concentration: > 5000000 nM
Compound 4: no number, only a limit (the forecaster's own chance of this, stated with the estimate: 60%); the middle value lies on the limit itself.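

In this assay, phenyl in place of ethyl on an amine nitrogen in a ring gives an at least 1.0-fold higher number from compound 3 to compound 4 (0.00 log units; that floor lies within the scatter). Compound 4 reaches only a limit, so this step is a floor and not a size, and the step on the core of compound 1 cannot be read either. The phenyl compounds on both cores therefore sit at the limit, which shows no readable effect of the change on either core but does not show that its size carries from one core to the other: the limit of > 5000000 nM in this assay, at which 3 of the 4 values shown sit.

Going by these compounds, whether any group on that amine nitrogen gives a number clearly clear of this limit stays open. A benzyl group, a longer chain or a carboxylic acid in that place is not among the compounds shown.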